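The compounds below may be only part of what the source reports. "The series", "measured", "known", "first", "only" and "open" are said of these compounds alone.

- Compound 1 `COc1cccc(CNCc2c(C(=O)O)n(Cc3ccc(C)cc3)c3ccccc23)c1`: 9330 nM
- Compound 2 `COc1ccc(Cn2c(C(=O)O)c(CN(C)Cc3cccc(OC)c3)c3ccc(C)cc32)cc1`: 7470 nM

In a functional assay on Bel7402/5-FU cells (Homo sapiens) for antiproliferative activity, read by MTT assay, with a stated time of 72 h (a lower number here means a stronger inhibitor, a higher number a weaker inhibitor), compound 2 gives 7470 nM, which lies within the usual scatter of compound 1 at 9330 nM, so the two cannot be told apart. Compound 3 `COc1ccc(Cn2c(C(=O)O)c(CNCc3cccc(O)c3)c3ccc(C)cc32)cc1` differs from compound 2 in one place: (3-hydroxybenzyl)amino in place of (3-methoxybenzyl)(methyl)amino on a saturated chain carbon bound to an aromatic carbon. That puts (3-hydroxybenzyl)amino in place of (3-methoxybenzyl)(methyl)amino on a saturated chain carbon bound to an aromatic carbon. For the measured compounds named here, no measured pair shows what a single change does in this assay, so no step beyond the scatter is expected, in either direction. The expected step, a 1.2-fold lower number from compound 2 to compound 3 (0.10 log units; within the scatter), is only an estimate. For compound 3 the estimated value is 6000 nM, with an expected range from 2000 nM to 18000 nM.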

Compound 3, half-maximal inhibitory concentration: > 50000 nM
Compound 3 was reported as a limit; the forecaster's own chance of this, stated with the estimate: 10%; middle value at least 8.3-fold (0.92 log units) away from the limit.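

In this assay, for the compounds shown here, this is the first single change whose effect can be read, and the amine on the saturated chain carbon bound to an aromatic carbon proves sensitive: (3-hydroxybenzyl)amino in place of (3-methoxybenzyl)(methyl)amino gives an at least 6.6-fold higher number from compound 2 to compound 3 (0.82 log units; beyond the scatter). Going by these compounds, the step is beyond the scatter, and its full size is unknown. Compound 3 is reported only as a limit, not a number: the limit of > 50000 nM in this assay, at which 1 of the 3 values shown sits.

On these data alone, the change swaps the methoxy for a hydroxy and removes the methyl on the nitrogen together, and which of these matters remains open. As far as these compounds go, how a 3-chlorobenzyl group on this amine would behave also remains open.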